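The source may report more compounds than this note shows. Statements on the series, on what has been measured and on what is new or still open speak of the compounds shown alone.

Values measured in an ADME assay on HCT-116 cells (Homo sapiens) for cytotoxicity, read by CellTiter-Glo, with a stated time of 72 h; on this read-out higher numbers stand for weaker inhibition and lower numbers for stronger inhibition:

- Compound 1 `CC1CCN(C2CCN(S(=O)(=O)c3cccc(N)c3)CC2)CC1`: > 5000 nM
- Compound 2 `CC1CCN(C2CCN(S(=O)(=O)c3nccn3C)CC2)CC1`: > 10000 nM

Both entries are limits, not numbers, so neither compound has a measured potency. Compound 3 `CC1CCN(C2CCN(S(=O)(=O)c3cccc(-c4ccc5ccccc5c4)c3)CC2)CC1` keeps the core of compound 1 and changes one group: naphthalen-2-yl in place of amino on an aromatic carbon. Within the data shown here, the only measured step is a step that the two limits leave unreadable from compound 1 to compound 2. That step concerns the group on the sulfonyl sulfur, not a substituent on the aromatic ring, and it provides no size to carry over. Compound 1 offers only its limit of > 5000 nM as a starting point. On the structural change alone, a shift toward stronger inhibition in this assay is expected, although another limit remains possible. The estimated step is an at least 1.6-fold lower number from compound 1 to compound 3 (0.22 log units; that floor lies within the scatter). For compound 3 the estimated value is 3000 nM, with an expected range of 500 nM to 10000 nM.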

Compound 3, half-maximal inhibitory concentration: > 5000 nM
Compound 3: a limit, no number; the forecaster's own chance of this, stated with the estimate: 40%; middle value at least 1.6-fold (0.22 log units) away from the limit.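

Compound 3 gives > 5000 nM in this assay, which is a limit and not a number; compound 1 also has only a limit, so no step can be read between compound 1 and compound 3. The compounds shown leave open what number any compound on this core would give in this assay.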